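Swapping trifluoromethyl for tert-butyl: cytotoxicity notes

The source may report more compounds than this note shows. Statements on the series, on what has been measured and on what is new or still open speak of the compounds shown alone.

Three compounds sharing one core differ only in a single group on an aromatic carbon. In an ADME assay on L6 cells (Rattus norvegicus) for cytotoxicity, read by resazurin assay, with a stated time of 70 h (on this read-out lower numbers stand for stronger inhibition and higher numbers for weaker inhibition), compound 1 `CC(=O)Oc1ccc2c(c1)C(C)=CC(C)(C)N2Cc1ccc(Cl)cc1` gives 22000 nM, compound 2 `CC(=O)Oc1ccc2c(c1)C(C)=CC(C)(C)N2Cc1ccc(C)cc1` gives 21000 nM and compound 3 `CC(=O)Oc1ccc2c(c1)C(C)=CC(C)(C)N2Cc1ccc(C(F)(F)F)cc1` gives 14000 nM. Compound 3 therefore cannot be separated from either of the other two, and all three numbers sit within the scatter of one another.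

The next compound is compound 4 `CC(=O)Oc1ccc2c(c1)C(C)=CC(C)(C)N2Cc1ccc(C(C)(C)C)cc1`, with tert-butyl in place of trifluoromethyl on an aromatic carbon. The place is unchanged: an aromatic carbon of a six-membered aromatic ring of carbon only, para to a large group.

For the measured compounds named here, three measured steps bear on this change, all made at that same place. They are a 1.0-fold lower number from compound 1 to compound 2 (0.02 log units; within the scatter), a 1.6-fold lower number from compound 1 to compound 3 (0.20 log units; within the scatter) and a 1.5-fold lower number from compound 2 to compound 3 (0.18 log units; within the scatter), and each lies within the scatter. Going by the values given here, no measured compound carries tert-butyl, so these steps offer only indirect guidance. Across these three compounds this assay has not responded to the group at this place, so no step beyond the scatter is expected.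

The expected change is a 1.2-fold higher number from compound 3 to compound 4 (0.08 log units; within the scatter). For compound 4 the estimated value is 17000 nM, with an expected range of 8000 nM to 35000 nM.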

Compound 4, half-maximal inhibitory concentration: 9000 nM
Beside the measured number, compound 4's estimate is 1.9-fold (0.28 log units) above it, within the range that was stated.
By their numbers in this assay, from the lowest: compounds 4, 3, 2 and 1 (each within the scatter of the next, the first and the last beyond it).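

In this assay, this position now gives its first steps beyond the scatter, both modest: tert-butyl in place of methyl gives a 2.3-fold lower number from compound 2 to compound 4 (0.37 log units; beyond the scatter), and tert-butyl in place of chloro gives a 2.4-fold lower number from compound 1 to compound 4 (0.39 log units; beyond the scatter). The change itself stays unresolved, since tert-butyl in place of trifluoromethyl gives a 1.6-fold lower number from compound 3 to compound 4 (0.19 log units; within the scatter), which lies within the scatter, so the assay separates tert-butyl from methyl and chloro but not from trifluoromethyl, while trifluoromethyl remains inseparable from all three other groups. Nothing available explains why tert-butyl parts from methyl and chloro at this place.

Still open, as far as these compounds go, is whether a group of another kind on this aromatic carbon, such as an amine, a carboxylic acid or a longer chain, would move the number further than tert-butyl does or in the opposite direction. Also open, from the compounds shown here alone, is whether the modest separation seen here would persist with changes elsewhere on the shared core, or whether it is specific to the core of compound 1.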